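Removing one side-chain methyl from compound 1

A few compounds are considered here, and "the series" means these few. Any claim that something is new, unique, unknown or untested is made for them only; others in the source may bear on it.

compound 1 `CC[C@H](C)[C@H](NC(=O)CN(c1nc(Cl)nc2[nH]cnc12)C1CC1)C(=O)O` — 30.3%
compound 2 `CC[C@H](C)[C@H](NC(=O)CN(c1nc(Cl)nc2[nH]cnc12)C1CC1)C(=O)OCc1ccccc1` — 41.4%

Among the measured compounds shown here, in a functional assay on the whole organism (Tail, strain ICR) with Mus musculus as the target, in the tail flick test, with a stated time of 30 min, at a dose of 25 umol/kg by the oral route (on this read-out lower numbers stand for a weaker effect and higher numbers for a stronger effect at the one dose given), compound 1 gives 30.3%, the lower of the two numbers measured so far. For the measured compounds named here, compound 2 gives 41.4%, the single measured step being a number 11.1 percentage points higher from compound 1 to compound 2 (beyond the scatter). Compound 3 `CC(C)[C@H](NC(=O)CN(c1nc(Cl)nc2[nH]cnc12)C1CC1)C(=O)O` differs from compound 1 by hydrogen in place of methyl on a saturated chain carbon, three bonds along the chain from an amide-type nitrogen and a carbonyl carbon. Going by the values given here, no measured step touches this part of the structure; the step from compound 1 to compound 2 changes a different group and gives no guidance here. In this assay no step beyond the scatter is therefore expected. Compound 3 is estimated at 30%, with a range of 15% to 45%. The expected step is a number 0.3 percentage points lower from compound 1 to compound 3 (within the scatter).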

Compound 3, a percentage reported as activity, at one dose (the size of the read-out at that dose, not a potency): 31.2%
For compound 3 the middle estimate is 1.2 percentage points below the measured one; low and high end bracket the measured number.
By their numbers in this assay, from the lowest: compounds 1 and 3 (each within the scatter of the next); then compound 2.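

In this assay, the change from sec-butyl to isopropyl gives no separable difference: a number 0.9 percentage points higher from compound 1 to compound 3 (within the scatter). At this one dose, the methyl on a saturated chain carbon, three bonds along the chain from an amide-type nitrogen and a carbonyl carbon, can therefore be lost with no step beyond the scatter. No measurement at hand accounts for this result. As far as these compounds go, whether a longer chain or an amine at this place would shift the number stays open. So does whether a benzyl ester of compound 3 would give a step like the one seen on compound 1.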